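The source may hold more compounds than are shown below. What is called first, only, known or untested is meant among the compounds shown, and "the series" means these compounds.

Compound 1 `COc1cc2cc(Oc3ccc(NC(=O)Nc4cccc(C(F)(F)F)c4)cc3)c(C)nc2cc1OC`: in a functional assay on UO-31 cells (Homo sapiens) for inhibition, read by sulforhodamine B assay, with a stated time of 48 h (a lower number here means that less compound is tolerated, a higher number that more compound is tolerated), compound 1 gives > 50000 nM, which is a limit of the assay rather than a number.
Compound 2 `COc1cc2cc(Oc3ccc(NC(=O)Nc4ccc(Cl)c(C(F)(F)F)c4)cc3)c(C)nc2cc1OC`: in this assay compound 2 gives 13400 nM.

Going by the values given here, compound 2 holds the only number measured in this assay; the other value is a limit, (the limit of > 50000 nM in this assay, at which 1 of the 2 values shown sits). Among the compounds with values here, the one measured step, an at least 3.7-fold lower number from compound 1 to compound 2 (0.57 log units; beyond the scatter), shows that a change on the same aryl ring can move the reading beyond the scatter.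

Compound 3 `COc1cc2cc(Oc3ccc(NC(=O)Nc4ccc(Cl)c(Cl)c4)cc3)c(C)nc2cc1OC` differs from compound 2 by chloro in place of trifluoromethyl on an aromatic carbon. Within the data shown here, no measured step exchanges these two groups, so the step from compound 1 to compound 2 bears on it only loosely: it shows that this ring is sensitive, not in which direction a swap of trifluoromethyl for chloro would act. A small step, if any, is therefore expected, and the estimated step is a 1.3-fold higher number from compound 2 to compound 3 (0.13 log units; within the scatter). Compound 3 is expected to give 18000 nM in this assay, with a likely range from 7000 nM to 50000 nM.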

Compound 3, concentration lethal to 50% of the cells: 79600 nM
The estimate for compound 3 lay 4.4-fold (0.65 log units) below the measured number, and the stated range ends below it.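

Swapping trifluoromethyl for chloro on this aromatic carbon gives a 5.9-fold higher number from compound 2 to compound 3 (0.77 log units; beyond the scatter) in this assay, so more compound is tolerated. Going by these compounds alone, the earlier step showed only that this aryl ring can move the reading, whereas this one shows that the trifluoromethyl group itself counts, even with the other chloro group held the same, and it gives the direction for this exchange. The step from compound 1 to compound 3 cannot be read, because the value of compound 1 is a limit and not a number: the limit of > 50000 nM in this assay, at which 1 of the 3 values shown sits.

The compounds shown leave open how other groups on this carbon, such as methyl, methoxy or a nitrile, would read. They also leave open whether the same exchange would give a similar step on a ring without the chloro group that compound 2 and compound 3 share.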